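The source may report more compounds than this note shows. Statements on the series, on what has been measured and on what is new or still open speak of the compounds shown alone.

Measured so far in a functional assay on HCT-116 cells (Homo sapiens) for cytotoxicity, read by MTT assay, with a stated time of 48 h; on this read-out lower numbers stand for stronger inhibition and higher numbers for weaker inhibition: compound 1 `Cc1ccc(-c2nn(-c3ccccc3)cc2C(=O)Nc2ccccc2)cc1` gives 2360 nM; compound 2 `COc1ccc(-c2nn(-c3ccccc3)cc2C(=O)Nc2ccc(Br)cc2)cc1` gives 5870 nM; compound 3 `O=C(Nc1ccccc1)c1cn(-c2ccccc2)nc1-c1ccc(Cl)cc1` gives 2180 nM.

Compound 3 stands lowest of the three numbers in this assay, but its nearest neighbour, compound 1, sits within the scatter of it, so no order between the two can be read; only compound 2 lies beyond the scatter, with the higher number. Going by the values given here, the one single-point step, a 1.1-fold lower number from compound 1 to compound 3 (0.03 log units; within the scatter), is within the scatter.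

Compound 4 `O=C(Nc1ccc(Br)cc1)c1cn(-c2ccccc2)nc1-c1ccc(Cl)cc1` differs from compound 3 by bromo in place of hydrogen on an aromatic carbon. Among the compounds with values here, no measured pair isolates this change. Compound 2 carries the same bromo on the anilide together with a methoxy on the other aryl, and the two values, compound 2 at 5870 nM against compound 3 at 2180 nM, show the higher number on the bromo compound, but two changes are bundled there. The step for compound 4 is therefore expected to be modest and upward, a 1.6-fold higher number from compound 3 to compound 4 (0.21 log units; within the scatter), uncertain in size. Compound 4 is estimated at 3500 nM, with a range from 1400 nM to 9000 nM.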

Compound 4, half-maximal inhibitory concentration: 4360 nM
Compound 4: the middle estimate sits 1.2-fold (0.10 log units) below what was measured, within the range that was stated.
By their numbers in this assay, from the lowest: compounds 3, 1, 4 and 2 (each within the scatter of the next, the first and the last beyond it).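

In this assay, the bromo for hydrogen change on the anilide ring, para to a large group, now stands alone in a single-point step, a 2.0-fold higher number from compound 3 to compound 4 (0.30 log units; within the scatter), and this lies within the scatter, so no effect of bromo can be read from this pair. On the bromo anilide, chloro in place of methoxy on the other aryl gives a 1.3-fold lower number from compound 2 to compound 4 (0.13 log units; within the scatter), also within the scatter, so this aryl position shows no readable change with either anilide, as the methyl to chloro step already showed on the plain anilide. Nothing on hand speaks to a cause for either step.

Open, from the compounds shown here alone, is whether an amine or a carboxylic acid at the bromo position would move the number beyond the scatter. The same question stands for the phenyl on the ring nitrogen, where all the compounds shown are alike.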